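The source may report more compounds than this note shows. Statements on the series, on what has been measured and on what is new or still open speak of the compounds shown alone.

In an ADME assay on a cell-free system (plasma, Homo sapiens) for protein binding, compound 1 `CNc1nccc(N2CC[C@H](NC(=O)Nc3ccc(Cl)c(C(F)(F)F)c3)C2)n1` gives 99.8%. Compound 2 `O=C(Nc1ccc(Cl)c(C(F)(F)F)c1)N[C@H]1CCN(c2ccnc(NC3CC3)n2)C1` gives > 99.9%, which is a limit of the assay and not a number, and so it stands at the limit of > 99.9% in this assay, at which 1 of the 2 values shown sits. Compound 3 `O=C(Nc1ccc(Cl)c(C(F)(F)F)c1)N[C@H]1CCN(c2ccncn2)C1` differs by hydrogen in place of cyclopropylamino on an aromatic carbon, with hydrogen in place of cyclopropylamino on an aromatic carbon. Among the measured compounds shown here, only one measured step touches this group, cyclopropyl in place of methyl on a nitrogen on an aromatic ring, which gave an at least 2.0-fold lower unbound fraction from compound 1 to compound 2 (0.30 log units; that floor lies within the scatter). That is a weak guide, but following its direction, more free compound is expected once the whole group leaves. The expected change is an at least 8.0-fold higher unbound fraction from compound 2 to compound 3 (0.90 log units; beyond the scatter). For compound 3 the estimate is 99.2%, with a range of 97.5% to 99.8%.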

Compound 3, plasma protein binding: 99.3%
Estimate against measurement, compound 3: 1.1-fold (0.06 log units) (unbound fraction) above, within the range that was stated.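

Compound 1 and compound 2 differ only in the group on the nitrogen, whereas compound 3 shows what happens when the whole amino substituent leaves this ring carbon. In this assay, hydrogen in place of cyclopropylamino gives an at least 7.0-fold higher unbound fraction from compound 2 to compound 3 (0.84 log units; beyond the scatter), and hydrogen in place of methylamino gives a 3.5-fold higher unbound fraction from compound 1 to compound 3 (0.54 log units; beyond the scatter), so both changes leave more compound free. The first step is only a floor, since the value of compound 2 is a limit of the assay: the limit of > 99.9% in this assay, at which 1 of the 3 values shown sits.

As far as these compounds go, it remains open how a plain amino group or a methoxy group at this position would compare with hydrogen.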